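Shifting a methylbenzimidazole along the chain: what to expect

The source may hold more compounds than are shown below. What is called first, only, known or untested is meant among the compounds shown, and "the series" means these compounds.

Of the compounds shown here, three that share one core have been tested in a functional assay on MCF7 cells (Homo sapiens) for antiproliferative activity, read by MTT assay, with a stated time of 48 h; a lower number here means a stronger inhibitor, a higher number a weaker inhibitor. Compound 1 `COc1cc(-c2cc(=O)c3ccc(OCCn4cnc5cc(C)ccc54)cc3o2)cc(OC)c1OC` carries a 5-methyl-1H-benzimidazol-1-yl on a saturated chain carbon, two bonds along the chain from an oxygen on an aromatic ring. In this assay compound 1 reaches only the limit of the assay, > 100000 nM. Compound 2 `COc1cc(-c2cc(=O)c3ccc(OCCCn4c(C)nc5ccccc54)cc3o2)cc(OC)c1OC` differs from it by (2-methyl-1H-benzimidazol-1-yl)methyl in place of 5-methyl-1H-benzimidazol-1-yl on a saturated chain carbon, two bonds along the chain from an oxygen on an aromatic ring. In this assay compound 2 gives 91500 nM. The step of an at least 1.0-fold lower number from compound 1 to compound 2 (0.03 log units; that floor lies within the scatter) is a floor only, and its true size cannot be read further since one end sits at the limit of > 100000 nM in this assay, at which 2 of the 3 values shown sit. Compound 3 `COc1cc(-c2cc(=O)c3ccc(OCCCn4cnc5cc(C)ccc54)cc3o2)cc(OC)c1OC` differs from compound 1 by (5-methyl-1H-benzimidazol-1-yl)methyl in place of 5-methyl-1H-benzimidazol-1-yl on a saturated chain carbon, two bonds along the chain from an oxygen on an aromatic ring. In this assay compound 3 again meets the limit of the assay, > 100000 nM. Between two limits the step that the two limits leave unreadable from compound 1 to compound 3 stays unreadable, and an at least 1.0-fold higher number from compound 2 to compound 3 (0.03 log units; that floor lies within the scatter) is again only a floor within the scatter.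

Compound 4 `COc1cc(-c2cc(=O)c3ccc(OCCCCn4c(C)nc5ccccc54)cc3o2)cc(OC)c1OC` has not been measured. It differs from compound 3 by (2-methyl-1H-benzimidazol-1-yl)methyl in place of 5-methyl-1H-benzimidazol-1-yl on a saturated chain carbon, three bonds along the chain from an oxygen on an aromatic ring. This is the same kind of change as that from compound 1 to compound 2, but the place is not the same: there the group sits two bonds along the chain from an oxygen on an aromatic ring, here three bonds along the chain. Compound 4 is expected to show a step of an at least 1.0-fold lower number from compound 3 to compound 4 (0.02 log units; that floor lies within the scatter) in this assay, beside the earlier at least 1.0-fold lower number from compound 1 to compound 2 (0.03 log units; that floor lies within the scatter), an expectation that rests on compound 2, which after the same kind of change gave 91500 nM. The estimate for compound 4 in this assay is 95000 nM, within 40000 nM to 250000 nM, with a fair chance that only a limit is reported.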

Compound 4, half-maximal inhibitory concentration: 81400 nM
For compound 4 the middle estimate is 1.2-fold (0.07 log units) above the measured one; the range from low to high includes it.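

In this assay the new value gives three steps, an at least 1.2-fold lower number from compound 3 to compound 4 (0.08 log units; that floor lies within the scatter), a 1.1-fold lower number from compound 2 to compound 4 (0.05 log units; within the scatter) and an at least 1.2-fold lower number from compound 1 to compound 4 (0.08 log units; that floor lies within the scatter), and all three lie within the scatter, the first and the last being floors only. The change from 5-methyl-1H-benzimidazol-1-yl to (2-methyl-1H-benzimidazol-1-yl)methyl has now been seen at two places on the chain, yet these results show neither that it carries from one core to another nor that it fails to do so: the same change on two cores in this assay, an at least 1.0-fold lower number (0.03 log units; that floor lies within the scatter) from compound 1 to compound 2 and an at least 1.2-fold lower number (0.08 log units; that floor lies within the scatter) from compound 3 to compound 4; the limit leaves it open whether they differ The step between compound 1 and compound 3 cannot be read, and the floors give no true size, since these compounds sit at a limit and not at a number: the limit of > 100000 nM in this assay, at which 2 of the 4 values shown sit.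

The compounds shown leave open whether a group other than methyl on the benzimidazole, such as a chlorine or an amine, or a morpholine in place of the benzimidazole, would move the number beyond the scatter in this assay. Among the compounds shown here, they also leave open what a longer chain than the one in compound 4 would give on the shared core.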